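Stereochemistry at the chain carbon of the propanamide series

The source may hold more compounds than are shown below. What is called first, only, known or untested is meant among the compounds shown, and "the series" means these compounds.

Compound 1 `CC(C(=O)NCc1ccc(C(F)(F)F)nc1N1CCC(c2ccccc2)CC1)c1ccc(NS(C)(=O)=O)c(F)c1` and compound 2 `C[C@@H](C(=O)NCc1ccc(C(F)(F)F)nc1N1CCC(c2ccccc2)CC1)c1ccc(NS(C)(=O)=O)c(F)c1` share every atom and bond. In a functional assay on CHO-K1 cells for antagonist activity at transient receptor potential cation channel subfamily V member 1 (Homo sapiens), read by FLIPR (on this read-out lower numbers stand for stronger inhibition and higher numbers for weaker inhibition), compound 1 gives 0.6 nM and compound 2 gives 7.5 nM. For the measured compounds named here, compound 2 therefore stands at the higher of the two numbers, and the only change between them is a 13-fold higher number from compound 1 to compound 2 (1.10 log units; beyond the scatter), which rests on the fact that one of compounds 1 and 2 is drawn with a defined configuration and the other without, at the place where they differ: compound 1 is drawn without a configuration at that carbon, compound 2 with the R configuration.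

Compound 3 `C[C@H](C(=O)NCc1ccc(C(F)(F)F)nc1N1CCC(c2ccccc2)CC1)c1ccc(NS(C)(=O)=O)c(F)c1` is the remaining case. Relative to compound 2 the change is the two compounds have the same atoms and bonds and differ only in configuration as drawn: 1 of 1 stereo elements differ; a stereocentre at a saturated chain carbon is drawn R in compound 2 and S in compound 3. Going by the values given here, the single measured step that bears on it is a 13-fold higher number from compound 1 to compound 2 (1.10 log units; beyond the scatter), a large one. Since compound 1, drawn without a configuration, returned a far lower number than the R isomer compound 2, the S isomer is the candidate to carry that activity, and a step in this assay of at least the size seen between compound 1 and compound 2, in the opposite direction, is expected.

Compound 3 is estimated at 0.3 nM, with a range from 0.1 nM to 1.5 nM. This corresponds to an expected step of a 25-fold lower number from compound 2 to compound 3 (1.40 log units; beyond the scatter).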

Compound 3, inhibition constant: 0.3 nM
Compound 3: middle estimate and measured number agree at the digits printed; low and high end bracket the measured number.
By their numbers in this assay, from the lowest: compounds 3 and 1 (each within the scatter of the next); then compound 2.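

The pair of defined isomers shows directly that configuration at this saturated chain carbon matters in this assay, with S in place of R giving a 25-fold lower number from compound 2 to compound 3 (1.40 log units; beyond the scatter), a large step with only one possible source: the fact that compounds 2 and 3 differ only in the configuration as drawn. The earlier step, a 13-fold higher number from compound 1 to compound 2 (1.10 log units; beyond the scatter), set the R isomer against a compound drawn without a configuration, so it could not compare the two configurations with each other: the fact that one of compounds 1 and 2 is drawn with a defined configuration and the other without, at the place where they differ. The new comparison with the undefined compound, a 2.0-fold lower number from compound 1 to compound 3 (0.30 log units; within the scatter), places compound 1 and compound 3 within the scatter of each other, so this assay does not tell them apart: the fact that one of compounds 1 and 3 is drawn with a defined configuration and the other without, at the place where they differ.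

From the compounds shown here alone, the isomeric composition of compound 1 remains unknown, so the closeness of compound 1 and compound 3 says nothing about how much of each isomer compound 1 contains. The compounds shown also leave open whether the gap between S and R persists when an ethyl group or a hydroxyl group replaces the methyl at this carbon, or when an amine or a carboxylic acid replaces the methanesulfonamide on the shared core.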